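The compounds below may be only part of what the source reports. "The series", "measured", "known", "first", "only" and "open" are said of these compounds alone.

Measured so far:
Compound 1, `Clc1ccc(/C=N/N(Cc2ccccc2)Cc2ccccc2)cc1`: 240 nM
Compound 2, `C(=N/N(Cc1ccccc1)Cc1ccccc1)\c1cccs1`: 1500 nM
Compound 3, `C(=N/N(Cc1ccccc1)Cc1ccccc1)\c1cccnc1`: 3700 nM

All three share a core in which a benzyl-bearing nitrogen is joined to a carbon carrying a ring, and they differ only in that ring. In an assay on liver (Sus scrofa) for inhibition of glucose-6-phosphatase catalytic subunit 1 (Homo sapiens), using microsomes (a higher number here means a weaker inhibitor, a lower number a stronger inhibitor), compound 3 has the highest number of the three, so it is the weakest inhibitor shown; compound 2 is nearest to it, and compound 1 furthest.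

Compound 4, `O=[N+]([O-])c1ccc(/C=N/N(Cc2ccccc2)Cc2ccccc2)o1`, has not been measured. It differs from compound 3 in one place: 5-nitrofuran-2-yl in place of pyridin-3-yl on a carbon with a double bond to nitrogen.

Among the compounds with values here, three measured steps concern this same position. Replacing the 4-chlorophenyl ring gave a 6.3-fold higher number from compound 1 to compound 2 (0.80 log units; beyond the scatter) and a 15-fold higher number from compound 1 to compound 3 (1.19 log units; beyond the scatter), and between the two heteroaryl rings there was a 2.5-fold higher number from compound 2 to compound 3 (0.39 log units; beyond the scatter). Each change of ring has moved the number beyond the scatter, so the step to compound 4 is expected to do so too. Since compound 3 sits at the top of the range, the number for compound 4 is expected to move down, with a step estimated as a 4.1-fold lower number from compound 3 to compound 4 (0.61 log units; beyond the scatter). The estimate for compound 4 is 900 nM, in a range from 250 nM to 4000 nM.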

Compound 4, half-maximal inhibitory concentration: > 100000 nM
Compound 4: no number, only a limit; the forecaster's own chance of this, stated with the estimate: 5%; middle value at least 110-fold (2.04 log units) away from the limit.
By their numbers in this assay, from the lowest: compound 1; then compound 2; then compound 3. At a limit, above all of these: compound 4.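

In this assay compound 4 gives no number, only a limit: the limit of > 100000 nM in this assay, at which 1 of the 4 values shown sits. The 5-nitrofuran-2-yl ring moves the number further than any earlier change of ring did, with an at least 27-fold higher number from compound 3 to compound 4 (1.43 log units; beyond the scatter), an at least 66-fold higher number from compound 2 to compound 4 (1.82 log units; beyond the scatter) and an at least 410-fold higher number from compound 1 to compound 4 (2.61 log units; beyond the scatter). The earlier rings all gave measurable inhibition and suggested that this position shifts the number only within a limited range, but compound 4 shows that a change of ring here can take the number out of the measurable range, and having a five-membered aromatic ring does not account for this, as compound 2 also has one and still gives a number.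

The compounds shown leave open whether the loss goes with the furan ring or with the nitro group. A plain furan-2-yl ring and a 4-nitrophenyl ring at this place would separate the two.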